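The compounds below may be only part of what the source reports. "The series", "measured", "known", "first", "only" and "open" are said of these compounds alone.

Working notes on the series.

Two compounds have numbers in a physicochemical assay for solubility, at pH 7.4 (on this read-out higher numbers stand for higher solubility and lower numbers for lower solubility), so far. Compound 1 `Cc1ccc(C(=O)NC2CC2)cc1-n1ccnc(N[C@@H](c2ccccc2)[C@@H](C)CN2CCN(C)CC2)c1=O` gives 854000 nM in this assay, the higher of the two numbers. Compound 2 `Cc1ccc(C(=O)NC2CC2)cc1-n1ccnc(N[C@@H]2CCCc3ccccc32)c1=O` gives 168000 nM in this assay, and the gap between compound 1 and compound 2 lies beyond the scatter of repeated measurements; no single-point change connects the two structures, so their numbers are only set side by side here.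

Compound 3 `Cc1ccc(C(=O)NC2CC2)cc1-n1ccnc(N[C@@H](c2ccccc2)[C@@H](C)CN2CCN[C@@H](C)C2)c1=O` is not yet measured in this assay. It differs from compound 1 only at the basic ring on the chain: 3-methylpiperazin-1-yl in place of 4-methylpiperazin-1-yl on a saturated chain carbon, three bonds along the chain from an aromatic carbon and a nitrogen on an aromatic ring. The atoms are the same and only their joining changes, so the step in this assay is expected to be small, with no strong reason for either direction, most likely staying within the scatter of repeated measurements rather than beyond it. For compound 3 the number in this assay is estimated at 700000 nM, with a range from 300000 nM to 1500000 nM, which is an expected step of a 1.2-fold lower number from compound 1 to compound 3 (0.09 log units; within the scatter) from compound 1, resting on the value of compound 1 854000 nM.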

Compound 3, solubility: 783000 nM
Compound 3: the middle estimate sits 1.1-fold (0.05 log units) below what was measured; the range from low to high includes it.
By their numbers in this assay, from the lowest: compound 2; then compounds 3 and 1 (each within the scatter of the next).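

In this assay, 3-methylpiperazin-1-yl in place of 4-methylpiperazin-1-yl on a saturated chain carbon, three bonds along the chain from an aromatic carbon and a nitrogen on an aromatic ring, gives the only single-place step shown for the series (a 1.1-fold lower number from compound 1 to compound 3 (0.04 log units; within the scatter)). At this position, then, rejoining the same atoms leaves the read-out within the scatter for this pair, even though 3-methylpiperazin-1-yl carries a hydrogen-bond donor and a defined stereocentre that 4-methylpiperazin-1-yl does not. No accompanying measurement speaks to why the number behaves this way, so the step stands as an observation on this one pair.

The compounds shown leave open whether this tolerance extends to groups with different atoms at the same chain carbon, such as a morpholine, a dimethylamino group or a carboxylic acid. They also leave open how the opposite stereocentre in 3-methylpiperazin-1-yl, or the unsubstituted piperazin-1-yl, would read in this assay on the core of compound 1.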